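This account rests on a few compounds, and the source may have more. Where it says the series, first, only, none or still open, it means among the compounds named here.

Working notes on the series in a physicochemical assay for lipophilicity, in phosphate buffer, measured as octanol-water partition, at pH 11.5; a lower number here means a more polar compound, a higher number a more lipophilic compound. Compound 1 `CCCCNC(=N)NC(=N)Nc1ccc(Cl)cc1` gives 3.13. Among the measured compounds shown here, compound 2 `CCCNC(=N)NC(=N)Nc1ccc(Cl)cc1` gives 2.63, the lowest of the three numbers measured so far; compound 1 is its nearest neighbour, and the gap between them is beyond the scatter. Compound 3 `CCCCCCCCNC(=N)NC(=N)Nc1ccccc1` gives 4.43 and lies furthest from compound 2, also well beyond the scatter. For the measured compounds named here, the only step measured between two compounds that differ in one place is a number 0.50 log units lower from compound 1 to compound 2 (beyond the scatter), a modest shift.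

Compound 4 `CCNC(=N)NC(=N)Nc1ccc(Cl)cc1` has not yet been measured in this assay. Compared with compound 2 it shows (hydrogen in place of methyl on a saturated chain carbon, two bonds along the chain from an amine nitrogen). This is the same kind of shortening already seen between compound 1 and compound 2, cut one bond further in along the chain, so that earlier step is the only measured one that bears on the expectation. Because a number 0.50 log units lower from compound 1 to compound 2 (beyond the scatter) was a modest step downward beyond the scatter, a downward step of similar size is expected here, namely a number 0.50 log units lower from compound 2 to compound 4 (beyond the scatter). On that basis compound 4 is expected to give 2.13 in this assay, with a range from 1.8 to 2.5.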

Compound 4, partition coefficient: 2.14
Compound 4: the middle estimate sits 0.01 log units below what was measured; the measured number falls inside the stated range.
By their numbers in this assay, from the lowest: compound 4; then compound 2; then compound 1; then compound 3.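

In this assay the cut from propylamino to ethylamino reads as a number 0.49 log units lower from compound 2 to compound 4 (beyond the scatter) and the earlier cut, one bond further out, reads as a number 0.50 log units lower from compound 1 to compound 2 (beyond the scatter) so the change of methyl to hydrogen gives a step of similar size at both places on the chain. Over the two cuts together the series shows a number 0.99 log units lower from compound 1 to compound 4 (beyond the scatter) and the number therefore falls in nearly even steps as the chain shortens, with none of these three compounds going against that, though three compounds describe only this short stretch of chain on the core of compound 1. Nothing on hand accounts for the evenness of these steps.

From the compounds shown here alone, what remains open is whether the even steps continue at the end of the chain, with a methyl group or a bare amine in place of ethylamino, and whether they hold for a branched chain such as isopropyl or a chain ending in a hydroxyl group. Compound 3 carries a much longer chain but differs from these compounds in a second place as well, so it cannot show whether the same step size extends along a longer chain on the same core.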